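The compounds below may be only part of what the source reports. "The series", "measured", "known", "first", "only" and "open" are said of these compounds alone.

Compound 1 `C[C@@H](O)[C@H]1C(=O)N2C(C(=O)OCOC(=O)O[C@@H]3CCc4ccccc43)=C(S[C@@H]3CN[C@H](C(=O)N(C)C)C3)[C@H](C)[C@H]12` carries the 2,3-dihydro-1H-inden-1-yl carbonate of the series. In a physicochemical assay for metabolic stability, read by HPLC, at pH 7.4, tested at 100 uM (a lower number here means that the compound disappears faster, a higher number that the compound lasts longer), compound 1 returns only a limit, < 0.0167 h, so its half-life is not a number but (the limit of < 0.0167 h in this assay, at which 1 of the 2 values shown sits). Compound 2 `CC(OC(=O)O[C@H]1CCCCc2ccccc21)OC(=O)C1=C(S[C@@H]2CN[C@H](C(=O)N(C)C)C2)[C@H](C)[C@@H]2[C@@H]([C@@H](C)O)C(=O)N12` is the other measured member; in this assay compound 2 gives 1.07 h. Compound 3 `C[C@@H](O)[C@H]1C(=O)N2C(C(=O)OCOC(=O)O[C@H]3CCCc4ccccc43)=C(S[C@@H]3CN[C@H](C(=O)N(C)C)C3)[C@H](C)[C@H]12` differs from compound 1 by 1,2,3,4-tetrahydronaphthalen-1-yl in place of 2,3-dihydro-1H-inden-1-yl on an oxygen next to a carbonyl group. For the measured compounds named here, no single-point step between measured compounds sizes this change, so the expected step from compound 1 to compound 3 is an at least 1.7-fold higher number from compound 1 to compound 3 (0.25 log units; that floor lies within the scatter), small and toward longer life but not claimed beyond the scatter. Compound 3 is accordingly estimated at 0.03 h, within 0.01 h to 0.15 h.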

Compound 3, half-life: 0.0233 h
Estimate against measurement, compound 3: 1.3-fold (0.11 log units) above, and the stated range covers the measured number.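

In this assay compound 3 gives 0.0233 h, a real number for the 1,2,3,4-tetrahydronaphthalen-1-yl group on an oxygen next to a carbonyl group. Exchanging 2,3-dihydro-1H-inden-1-yl for this group gives an at least 1.3-fold higher number from compound 1 to compound 3 (0.14 log units; that floor lies within the scatter), the first step read at this position, and it does not establish a change beyond the scatter.

Going by these compounds, compound 1 holds only a limit, so the upper size of the step stays open: the limit of < 0.0167 h in this assay, at which 1 of the 3 values shown sits. Also open is whether an open n-butyl chain or a cyclohexyl group on the same oxygen would shift the half-life beyond the scatter.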